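Fluoro for chloro on the sulfonyl aryl group

The compounds below may be only part of what the source reports. "The series", "measured", "known", "first", "only" and "open" are said of these compounds alone.

Working notes on the series, with two compounds read so far in a functional assay on HL-60 cells (Homo sapiens) for inhibition, read by CCK-8 assay, with a stated time of 48 h, tested at 20 uM (on this read-out lower numbers stand for less inhibition of growth and higher numbers for more inhibition of growth at the one concentration tested), as the only test. Compound 2 (`N#C/C(=C\c1ccccc1OS(=O)(=O)c1ccc(Cl)cc1)C(=O)Nc1nnc(Cc2ccccc2)s1`) gives 26% and stands highest of the two. Compound 1 (`N#C/C(=C\c1ccccc1OS(=O)(=O)c1ccc(F)cc1)C(=O)Nc1nnc(Cc2cccc3ccccc23)s1`) gives 12% in this assay and this gap lies beyond the usual scatter. The two compounds differ in more than one place, so the gap cannot be tied to a single change.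

Compound 3 (`N#C/C(=C\c1ccccc1OS(=O)(=O)c1ccc(F)cc1)C(=O)Nc1nnc(Cc2ccccc2)s1`) departs from compound 2 in one place only, with fluoro in place of chloro on an aromatic carbon, para to a large group (fluoro in place of chloro on an aromatic carbon). Going by the values given here, no measured pair isolates this exchange. Compound 1 also carries fluoro and gives 12% in this test, but its other difference from compound 3 leaves that reading a weak guide. The estimated change is a number 4 percentage points lower from compound 2 to compound 3 (within the scatter) and this is expected to be a slight fall that stays within the scatter. For compound 3 the estimated reading is 22% with 10% to 36% as the expected range.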

Compound 3, percent growth inhibition at one concentration: 22%
Compound 3: the middle estimate sits on the measured number at the digits printed; measured number inside the range.
By their numbers in this assay, from the lowest: compounds 1, 3 and 2 (each within the scatter of the next, the first and the last beyond it).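

In this assay the exchange of 4-chlorophenyl to 4-fluorophenyl gives a number 4 percentage points lower from compound 2 to compound 3 (within the scatter), so at the one concentration tested this aromatic carbon does not separate fluoro from chloro. A second single exchange can now be read as well: phenyl in place of naphthalen-1-yl on a saturated chain carbon bound to an aromatic carbon gives a number 10 percentage points higher from compound 1 to compound 3 (within the scatter), so this pair cannot be separated either, and neither exchange has a clear effect on the reading. No measurement is at hand that would account for either step.

As far as these compounds go, whether an amine or a methoxy group in place of fluoro on that aromatic carbon would carry the reading beyond the scatter remains open. Also open is whether the exchange of chloro for fluoro reads the same with naphthalen-1-yl in place of phenyl, since the compounds shown include only the fluoro member of that pair.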